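Adding a Hydroxy Group to a Cytotoxicity-Tolerant Scaffold

A few compounds are considered here, and "the series" means these few. Any claim that something is new, unique, unknown or untested is made for them only; others in the source may bear on it.

Compound 1 `c1ccc(-c2nc3ccccn3c2NC2CCOC2)nc1` and compound 2 `Fc1cccc(Nc2c(-c3ccccn3)nc3ccccn23)c1` share one core and differ at a single nitrogen. In an ADME assay on THP-1 cells (Homo sapiens) for cytotoxicity (a higher number here means that more compound is tolerated, a lower number that less compound is tolerated), compound 1 gives only a limit, > 50000 nM. In this assay compound 2 likewise gives only a limit, > 50000 nM. Among the measured compounds shown here, the one step between them, a step that the two limits leave unreadable from compound 1 to compound 2, is therefore unreadable, and the limit of > 50000 nM in this assay, at which 2 of the 2 values shown sit, records only that both measurements stop there. Compound 2 thus stands at a limit, with no number attached to it.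

Compound 3 `Oc1ccn2c(Nc3cccc(F)c3)c(-c3ccccn3)nc2c1` differs from compound 2 in one place: hydroxy in place of hydrogen on an aromatic carbon. For the measured compounds named here, no measured step bears on this change; the only step available, a step that the two limits leave unreadable from compound 1 to compound 2, concerns a different position and its size cannot be read. There is accordingly no ground to expect a step beyond the scatter in this assay in either direction. Compound 3 is expected to sit at the same limit as compound 2, which as a step means a number no higher from compound 2 to compound 3 (the limit leaves the size open). The estimate for compound 3 in this assay is 50000 nM, with a range from 20000 nM to 150000 nM.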

Compound 3, half-maximal cytotoxic concentration: 43300 nM
For compound 3 the middle estimate is 1.2-fold (0.06 log units) above the measured one; low and high end bracket the measured number.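

Compound 3 gives 43300 nM in this assay, the first value among these compounds that is a number and not a limit. At this aromatic carbon, opposite the ring nitrogen and para to a fused ring, hydroxy in place of hydrogen gives an at least 1.1-fold lower number from compound 2 to compound 3 (0.06 log units; that floor lies within the scatter), so this change can be tied to a readable lower bound, although that bound does not establish a real change. How far the step extends remains unknown because the starting point, compound 2, is only a limit, as is compound 1: the limit of > 50000 nM in this assay, at which 2 of the 3 values shown sit.

The compounds shown leave open whether a methoxy group, an amine or a carboxylic acid on the same carbon would give a number close to that of compound 3 or one clearly lower in this assay. They also leave open whether hydroxy at this position would give a readable number with oxolan-3-yl on the nitrogen, as in compound 1, in place of the 3-fluorophenyl group.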